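A few compounds are considered here, and "the series" means these few. Any claim that something is new, unique, unknown or untested is made for them only; others in the source may bear on it.

Measured in a functional assay on L1210 cells (Mus musculus) for cytotoxicity, read by MTT assay, with a stated time of 24 h; on this read-out lower numbers stand for stronger inhibition and higher numbers for weaker inhibition:
- compound 1 `COc1cc(C(=O)/C=C/c2ccc(Cl)cc2)cc(OC)c1OC`: 44500 nM
- compound 2 `COc1cc(OC)c(OC)cc1/C=C/C(=O)c1cc(OC)c(OC)c(OC)c1`: 42500 nM
- compound 3 `COc1cc(/C=C/C(=O)c2cc(OC)c(OC)c(OC)c2)ccc1O`: > 100000 nM

In this assay compound 1 gives 44500 nM, and compound 2 gives 42500 nM, so these two numbers lie within the usual scatter of each other. Compound 3 yields no number, only the limit > 100000 nM.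

The next compound is compound 4 `COc1cc(C(=O)/C=C/c2cc(Cl)cc(Cl)c2)cc(OC)c1OC`, still unmeasured. It keeps the core of compound 1 and carries 3,5-dichlorophenyl in place of 4-chlorophenyl on a double-bonded chain carbon bound to a double-bonded chain carbon.

Among the compounds with values here, no pair of measured compounds differs in one place, so the data offer no direct guide to the size of this step. The expectation therefore starts from compound 1 at 44500 nM, and no change beyond the scatter is foreseen in this assay. The expected step is a 1.3-fold lower number from compound 1 to compound 4 (0.10 log units; within the scatter). For compound 4 the estimated value is 35000 nM, with an expected range from 12000 nM to 90000 nM.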

Compound 4, half-maximal inhibitory concentration: 44000 nM
Compound 4: the middle estimate sits 1.3-fold (0.10 log units) below what was measured; the measured number falls inside the stated range.
By their numbers in this assay, from the lowest: compounds 2, 4 and 1 (each within the scatter of the next). At a limit, above all of these: compound 3.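

In this assay, within the data shown here, putting 3,5-dichlorophenyl in place of 4-chlorophenyl on a double-bonded chain carbon bound to a double-bonded chain carbon gives a 1.0-fold lower number from compound 1 to compound 4 (0.00 log units; within the scatter), the first change in one place that can be read. Among these compounds, at this position, then, the chlorine pattern of the phenyl ring can change, and a second chlorine can enter, without a shift beyond the scatter, which the earlier compounds could not show. Nothing shown here gives a reason for this result.

As far as these compounds go, both phenyl groups compared carry chlorine alone, so it remains open whether any group at this position can move the number beyond the scatter. From the compounds shown here alone, an amine or a carboxylic acid on this ring, or a longer chain in place of the ring, would be a much larger change, and its effect remains unknown.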